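A few compounds are considered here, and "the series" means these few. Any claim that something is new, unique, unknown or untested is made for them only; others in the source may bear on it.

Measured so far in a functional assay on MDA-MB-231 cells (Homo sapiens) for inhibition, read by sulforhodamine B assay, tested at 10 uM; on this read-out lower numbers stand for less inhibition and higher numbers for more inhibition at the one concentration tested (going by the name of the read-out):
Compound 1 `Cc1ccc(S(=O)(=O)N2N=C(c3ccc(-n4cncn4)cc3)CC2c2ccc(N(C)C)cc2)cc1` gives 20.7%.
Compound 2 `COC(=O)CC(=O)N1N=C(c2ccc(-n3ccnc3)cc2)CC1c1ccc(N(C)C)cc1` gives 2.3%.
Compound 3 `CN(C)c1ccc(C2CC(c3ccc(-n4ccnc4)cc3)=NN2C(=O)c2ccc(C(F)(F)F)cc2)cc1` gives 17.9%.

On these three numbers compound 3 sits within the usual scatter of compound 1 and beyond the scatter above compound 2. The next compound, compound 4 `Cc1ccc(S(=O)(=O)N2N=C(c3ccc(-n4ccnc4)cc3)CC2c2ccc(N(C)C)cc2)cc1`, keeps the 4-(1H-imidazol-1-yl)phenyl group of compound 3 and changes only the group on the amine nitrogen in the ring: (4-methylphenyl)sulfonyl in place of (4-(trifluoromethyl)phenyl)carbonyl on an amine nitrogen in a ring. Going by the values given here, one measured step touches this same position: a number 15.6 percentage points higher from compound 2 to compound 3 (beyond the scatter). That step swapped a different pair of groups, so it shows only that this position can move the read-out by a modest amount, not which way the present change goes. Compound 1 carries the very (4-methylphenyl)sulfonyl group that enters here, and its value lies within the scatter of compound 3. The step is therefore expected to stay within the scatter: a number 2.1 percentage points higher from compound 3 to compound 4 (within the scatter). Compound 4 is expected to give about 20%, between 8% and 32%.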

Compound 4, a percentage reported as inhibition, at one concentration (the size of the read-out at that concentration, not a potency): 50.8%
Estimate against measurement, compound 4: 30.8 percentage points below; the whole stated range lies below it.
By their numbers in this assay, from the lowest: compound 2; then compounds 3 and 1 (each within the scatter of the next); then compound 4.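

In this assay, putting (4-methylphenyl)sulfonyl on the amine nitrogen in the ring gives a number 32.9 percentage points higher from compound 3 to compound 4 (beyond the scatter), and the same group measured against ((methoxycarbonyl)methyl)carbonyl gives a number 48.5 percentage points higher from compound 2 to compound 4 (beyond the scatter), so with the 4-(1H-imidazol-1-yl)phenyl group in place, this position can move the read-out by a large amount. The sulfonyl group does not settle the result alone: with it held fixed, 1H-imidazol-1-yl in place of 1H-1,2,4-triazol-1-yl gives a number 30.1 percentage points higher from compound 1 to compound 4 (beyond the scatter), so a change at the far aromatic ring matters just as much. Nothing available explains why either change has this effect.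

Still open, going by these compounds, is whether the imidazole gain would also appear with a carbonyl group on the ring nitrogen. On these data alone, it is equally open how a smaller methylsulfonyl group, or a 4-chlorophenylsulfonyl group, would compare at this position.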